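The compounds below may be only part of what the source reports. "The series", "measured", "known", "first", "only" and "open" are said of these compounds alone.

In an assay on Prostate gland for inhibition of steroid 5-alpha-reductase (Rattus norvegicus) (on this read-out lower numbers stand for stronger inhibition and higher numbers for weaker inhibition), the measured compounds are: compound 1 `CCCCc1ccc(Cn2ccc3cc(/C(C)=C/C(=O)Nc4ccccc4OCCCC(=O)O)ccc32)cc1`, 100 nM; compound 2 `CCCCCC(c1ccccc1)n1ccc2cc(/C(C)=C/C(=O)Nc3ccccc3OCCCC(=O)O)ccc21`, 25 nM.

On these numbers compound 2 stands lowest of the two, separated from compound 1 by a 4.0-fold lower number from compound 1 to compound 2 (0.60 log units; beyond the scatter). Compound 3 `C/C(=C\C(=O)Nc1ccccc1OCCCC(=O)O)c1ccc2c(ccn2C(c2ccccc2)c2ccccn2)c1` differs from compound 2 by pyridin-2-yl in place of pentyl on a saturated chain carbon bound to an aromatic carbon and an aromatic nitrogen. For the measured compounds named here, no measured step touches this change; the only step available, a 4.0-fold lower number from compound 1 to compound 2 (0.60 log units; beyond the scatter), concerns a different substituent on the aromatic nitrogen and bears on it only loosely. In this assay a step of at most modest size in either direction, or none beyond the scatter, is therefore expected. For compound 3 the estimate is 40 nM, within 12 nM to 150 nM, which means an expected 1.6-fold higher number from compound 2 to compound 3 (0.20 log units; within the scatter).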

Compound 3, half-maximal inhibitory concentration: 37 nM
Beside the measured number, compound 3's estimate is 1.1-fold (0.03 log units) above it, and the stated range covers the measured number.
By their numbers in this assay, from the lowest: compounds 2 and 3 (each within the scatter of the next); then compound 1.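

At the saturated chain carbon bound to an aromatic carbon and an aromatic nitrogen, pyridin-2-yl stands in place of pentyl with a 1.5-fold higher number from compound 2 to compound 3 (0.17 log units; within the scatter) in this assay. This position therefore takes a six-membered aromatic ring with one hetero atom as well as an open chain, with no difference beyond the scatter. No evidence at hand explains why the two groups read alike.

Left open is whether pyridin-3-yl, pyridin-4-yl or a shorter propyl chain would read the same on this carbon. An amine or a carboxylic acid there also remains untested among the compounds shown.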